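The source may hold more compounds than are shown below. What is called first, only, known or untested is meant among the compounds shown, and "the series" means these compounds.

In an ADME assay on MT4 cells (Homo sapiens) for cytotoxicity, read by MTT assay (a lower number here means that less compound is tolerated, a higher number that more compound is tolerated), compound 1 `CCCCC1C(=O)N(O)C(=O)c2ccccc21` stands at 25400 nM as the lowest of three numbers, against compound 2 `O=C1c2ccccc2C(Cc2ccccc2)C(=O)N1O` at 95000 nM and compound 3 `CC1C(=O)N(O)C(=O)c2ccccc21` at 250000 nM on the same read-out. Compound 4 `O=C1c2ccccc2C(CCCc2ccccc2)C(=O)N1O` differs from compound 1 by phenyl in place of methyl on a saturated chain carbon, three bonds along the chain from a saturated ring carbon in one place: phenyl in place of methyl on a saturated chain carbon, three bonds along the chain from a saturated ring carbon.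

Within the data shown here, three measured steps bear on this change, all modest and all made at a single place on the shared core. Hydrogen in place of propyl gave a 9.8-fold higher number from compound 1 to compound 3 (0.99 log units; beyond the scatter) while hydrogen in place of phenyl gave a 2.6-fold higher number from compound 2 to compound 3 (0.42 log units; beyond the scatter) on the same read-out, so among these three compounds the smallest group goes with the highest number. Phenyl in place of propyl gave a 3.7-fold higher number from compound 1 to compound 2 (0.57 log units; beyond the scatter) and so shows that a phenyl on a short chain did not reach the number of compound 1. Among the measured compounds shown here, compound 4 keeps the chain of compound 1 and ends it in phenyl, a placement that no measured step covers. A small step or none is therefore expected. The estimated step is a 1.2-fold lower number from compound 1 to compound 4 (0.06 log units; within the scatter) and it is expected to stay within the scatter. Compound 4 is expected in this assay at about 22000 nM (estimated range 8000 nM to 60000 nM).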

Compound 4, half-maximal cytotoxic concentration: 5200 nM
Estimate against measurement, compound 4: 4.2-fold (0.63 log units) above; measured number below the stated range.
By their numbers in this assay, from the lowest: compound 4; then compound 1; then compound 2; then compound 3.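

Ending the chain in phenyl gave a 4.9-fold lower number from compound 1 to compound 4 (0.69 log units; beyond the scatter) in this assay, so at this place on a saturated chain carbon, three bonds along the chain from a saturated ring carbon, the change moved the number down. Phenyl in place of propyl had moved it the other way in a 3.7-fold higher number from compound 1 to compound 2 (0.57 log units; beyond the scatter), which shows that the phenyl does not go with one direction and that the outcome differs with the place where it enters. Compound 4 now holds the lowest number of the four, and although compound 3, with the smallest group, still holds the highest, compound 2 goes against any simple order by group size, since it stands above compound 1; nothing given here accounts for the direction of either step.

The compounds shown leave open whether a longer chain ending in phenyl would take the number lower still or whether the trend stops at compound 4. They also leave open whether an amine or a carboxylic acid in place of that phenyl would keep the lower number.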